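The source may hold more compounds than are shown below. What is called first, only, known or untested is meant among the compounds shown, and "the series" means these compounds.

Compound 3, whose structure is `COc1ccc(NC(=O)CCc2nc(Cc3ccc(NC(C)=O)cc3)no2)cc1OC`, stands highest of the three compounds measured in a functional assay on the whole organism (strain C57BL/6) for inhibition, with Mus musculus as the target, read by paw edema, with stated times of 1 h and 4 h, at a dose of 100 mg/kg by the oral route; on this read-out lower numbers stand for less inhibition and higher numbers for more inhibition at the one dose given (going by the name of the read-out). In this assay compound 3 gives 95.9%, against 49.3% for compound 1, `COc1ccc(NC(=O)CCc2nc(Cc3ccc(NC(C)=O)cc3)no2)cc1`, and 60.3% for compound 2, `COc1ccc(NC(=O)CCc2nc(Cc3ccc(NC(C)=O)cc3)no2)cc1F`. The steps leading up to compound 3 were both sizeable: a number 46.6 percentage points higher from compound 1 to compound 3 (beyond the scatter), and a number 35.6 percentage points higher from compound 2 to compound 3 (beyond the scatter); the smaller step of a number 11 percentage points higher from compound 1 to compound 2 (beyond the scatter) also lies beyond the scatter.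

Compound 4, `CC(=O)Nc1ccc(Cc2noc(CCC(=O)Nc3cccc(C)c3)n2)cc1`, differs from compound 3 in one place: 3-methylphenyl in place of 3,4-dimethoxyphenyl on an amide-type nitrogen. This change strips away the very group whose arrival carried compound 1 and compound 2 up to compound 3, and replaces it with a group carrying no methoxy at all, which is also less than compound 1 retains. The steps from compound 1 and compound 2 to compound 3 therefore bear on it directly, read in reverse. A large downward step is expected, a number 50.9 percentage points lower from compound 3 to compound 4 (beyond the scatter), landing compound 4 near the level of compound 1 or somewhat below it. Compound 4 is thus estimated at 45%, with a range from 25% to 68%.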

Compound 4, a percentage reported as inhibition, in the whole organism at one dose (the size of the read-out at that dose, not a potency): 16.4%
Estimate against measurement, compound 4: 28.6 percentage points above; measured number outside the range, below it.
By their numbers in this assay, from the lowest: compound 4; then compound 1; then compound 2; then compound 3.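

Compound 4 is the only compound shown with no methoxy on the aromatic ring on the amide-type nitrogen, and in this assay its 3-methylphenyl stands lowest of the four groups at this place, with a number 79.5 percentage points lower from compound 3 to compound 4 (beyond the scatter) and a number 43.9 percentage points lower from compound 2 to compound 4 (beyond the scatter) and a number 32.9 percentage points lower from compound 1 to compound 4 (beyond the scatter) as its steps. Even the single methoxy of 4-methoxyphenyl therefore stands clearly above 3-methylphenyl, so the number at this place can fall well beneath the level of the earlier compounds, all of which held a methoxy. Nothing available here explains why the number falls so far with this group.

The compounds shown leave open whether the methyl itself lowers the number or whether the absence of methoxy is enough, a question that plain phenyl at this place would separate. Also open, on these data alone, is how an amine or a carboxylic acid on this ring would stand.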